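Replacing a fluorophenyl with a methoxyphenylamino group

The source may hold more compounds than are shown below. What is called first, only, known or untested is meant among the compounds shown, and "the series" means these compounds.

For the measured compounds named here, compound 2 `Cc1ccc(S(=O)(=O)N(Cc2nnc(Cc3ccc(F)cc3)o2)c2cccc(Cl)c2C)cc1` stands at the lower of the two numbers measured so far. In a functional assay on CHO cells for antagonist activity at prostaglandin E2 receptor EP1 subtype (Homo sapiens), read by FLIPR and calcium flux (on this read-out lower numbers stand for stronger inhibition and higher numbers for weaker inhibition), compound 2 gives 501 nM. Its only companion, compound 1 `CCc1ccccc1N(Cc1nnc(Cc2ccc(OC)cc2)o1)S(=O)(=O)c1ccc(C)cc1`, gives in this assay a value of 631 nM, and the gap between the two lies within the scatter, so neither can be set above the other.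

Compound 3 `COc1ccc(NCc2nnc(CN(c3cccc(Cl)c3C)S(=O)(=O)c3ccc(C)cc3)o2)cc1` has not yet been measured. It differs from compound 2 by (4-methoxyphenyl)amino in place of 4-fluorophenyl on a saturated chain carbon bound to an aromatic carbon. Going by the values given here, no step between two measured compounds is known here, so there is nothing to show how such a change shifts the numbers in this assay. The step from compound 2 to compound 3 is expected to be small, a 1.4-fold higher number from compound 2 to compound 3 (0.15 log units; within the scatter), and not clearly beyond the scatter in either direction. Compound 3 is therefore estimated at 700 nM in this assay, with a range from 200 nM to 2500 nM.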

Compound 3, inhibition constant: 79.4 nM
Estimate against measurement, compound 3: 8.8-fold (0.95 log units) above, and the stated range ends above it.
By their numbers in this assay, from the lowest: compound 3; then compounds 2 and 1 (each within the scatter of the next).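

In this assay, the position on a saturated chain carbon bound to an aromatic carbon proves responsive: (4-methoxyphenyl)amino in place of 4-fluorophenyl gives a 6.3-fold lower number from compound 2 to compound 3 (0.80 log units; beyond the scatter). For the compounds shown here, the earlier compounds offered no step that could show this, so this is the first evidence that a change at this place can move the number beyond the scatter. Nothing available here explains the shift.

This one change brings in the amino nitrogen and replaces fluorine with methoxy on the ring together, and the compounds shown do not separate the two. As far as these compounds go, it remains open whether a fluorophenylamino group, or an ether oxygen in place of the amine nitrogen, would give a step of similar size.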